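Swapping the Amide Aryl Group: Expected Solubility of Compound 4

The compounds below may be only part of what the source reports. "The series", "measured", "known", "first", "only" and "open" are said of these compounds alone.

Of the compounds shown here, three built on a shared core have been measured in a physicochemical assay for solubility, in phosphate buffer, measured as kinetic solubility, with a stated time of 1 h, at pH 7.4; on this read-out lower numbers stand for lower solubility and higher numbers for higher solubility. Compound 1 `Cc1cc(C)cc(NC(=O)COc2cc(C)nc3ccc(C)cc23)c1` gives 83000 nM, compound 2 `COc1ccc2nc(C(F)(F)F)cc(OCC(=O)Nc3cc(C)cc(C)c3)c2c1` gives 15000 nM, and compound 3 `COc1cccc(NC(=O)COc2cc(C)nc3ccc(OC)cc23)c1` gives 35000 nM. Compound 3 stands second highest of the three: its number lies beyond the usual scatter both from compound 2, which is lower, and from compound 1, which is higher. Compound 4 `COc1ccc2nc(C)cc(OCC(=O)Nc3ccc(F)cc3)c2c1` is still to be measured in this assay. It differs from compound 3 in one place: 4-fluorophenyl in place of 3-methoxyphenyl on an amide-type nitrogen. Going by the values given here, no measured pair here shows the effect of such a swap, so the direction is uncertain; a modest fall is expected, though a step within the scatter is equally plausible. For compound 4 the expected solubility is 25000 nM, between 8000 nM and 70000 nM. This means an expected step of a 1.4-fold lower number from compound 3 to compound 4 (0.15 log units; within the scatter).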

Compound 4, solubility: 104000 nM
Compound 4: middle estimate off by 4.2-fold (0.62 log units), on the low side, and the stated range ends below it.
By their numbers in this assay, from the lowest: compound 2; then compound 3; then compounds 1 and 4 (each within the scatter of the next).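

In this assay, going by these compounds alone, the aryl group on the amide-type nitrogen turns out to matter: 4-fluorophenyl in place of 3-methoxyphenyl gives a 3.0-fold higher number from compound 3 to compound 4 (0.47 log units; beyond the scatter), the only single-place step in this set. The change therefore raises the number rather than lowering it, at least for this one pair on this core. No measurement here offers a reason for the rise.

On these data alone, this one swap changes the substituent and its ring position together, so their separate contributions remain open. Also open, as far as these compounds go, is how a plain phenyl, or a phenyl carrying an amine or a carboxylic acid, would behave at this nitrogen.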